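Quinoxaline-free notes: a diarylamino series, cytotoxicity on liver cells

This account rests on a few compounds, and the source may have more. Where it says the series, first, only, none or still open, it means among the compounds named here.

Measured so far in a toxicity assay on HepG2 cells (Homo sapiens) for cytotoxicity, read by MTT assay, with a stated time of 72 h; on this read-out higher numbers stand for lower toxicity in this test and lower numbers for higher toxicity in this test:
- compound 1 `Brc1ccc(Nc2nc3ccccc3nc2Nc2ccc(Br)cc2)cc1` gives 4640 nM
- compound 2 `Nc1ccc2nc(Nc3ccc(Cl)c(Cl)c3)c(Nc3ccc(Cl)c(Cl)c3)nc2c1` gives "nd" (no result reported), that is, no number; the result is recorded as not determined
- compound 3 `O=[N+]([O-])c1ccc2nc(Nc3cccc(C(F)(F)F)c3)c(Nc3cccc(C(F)(F)F)c3)nc2c1` gives 900 nM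

Compound 1 and compound 3 carry different halogen-type substituents on their two aryl amines and differ on the shared core as well, so their two values show only that both fall in the same broad region of this assay, with compound 3 reading lower than compound 1. Compound 2 stands nowhere on the numbers: it has no measured value, so its position relative to compound 1 and compound 3 is open.

Compound 4 `O=C(Nc1ccc2nc(Nc3ccc(Cl)c(Cl)c3)c(Nc3ccc(Cl)c(Cl)c3)nc2c1)c1ccco1` is not yet measured. It differs from compound 2 by (furan-2-yl)carbonyl in place of hydrogen on a nitrogen on an aromatic ring. For the measured compounds named here, no measured pair in the set shows this kind of change, so the size of the step from compound 2 to compound 4 in this assay cannot be read off; a step that stays within the usual scatter, in either direction, is as plausible as a modest one.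

Resting only on the two measured values, compound 4 is expected to give about 2000 nM in this assay, with an expected range from 500 nM to 8000 nM.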

Compound 4, half-maximal cytotoxic concentration: 5690 nM
Beside the measured number, compound 4's estimate is 2.8-fold (0.45 log units) below it; the range from low to high includes it.
By their numbers in this assay, from the lowest: compound 3; then compounds 1 and 4 (each within the scatter of the next).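

In this assay compound 4 gives 5690 nM but compound 2 has no number to set against it, so no step can be read from compound 2 to compound 4. The size and direction of the change from amino to ((furan-2-yl)carbonyl)amino stay open in the compounds shown. No evidence at hand bears on this result.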